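A few compounds are considered here, and "the series" means these few. Any claim that something is new, unique, unknown or untested is made for them only; others in the source may bear on it.

In an assay on ileum with muscarinic acetylcholine receptor M3 (Cavia porcellus) as the target (a lower number here means a stronger inhibitor, a higher number a weaker inhibitor), compound 1 `NC(=O)C(CCn1ccnc1)(c1ccccc1)c1ccccc1` gives 5.07 nM, the second highest of the three numbers measured. Compound 2 `Cc1ncn(CCC(C(N)=O)(c2ccccc2)c2ccccc2)c1C` gives 2.7 nM, and a 1.9-fold lower number from compound 1 to compound 2 (0.27 log units; within the scatter). Compound 3 `CCCc1ncn(CCC(C(N)=O)(c2ccccc2)c2ccccc2)c1CCC` gives 100 nM, a far higher number than compound 1 shows. Compound 4 `Cc1cn(CCC(C(N)=O)(c2ccccc2)c2ccccc2)cn1` differs from compound 1 by methyl in place of hydrogen on an aromatic carbon. Within the data shown here, only the step from compound 1 to compound 2 bears directly on this change, and it stayed within the scatter, while the two propyl groups of compound 3 went with a much weaker number. A single methyl is expected to leave the number near that of compound 1, with no shift beyond the scatter. The expected step is a 1.3-fold lower number from compound 1 to compound 4 (0.10 log units; within the scatter). Compound 4 is therefore estimated at 4 nM, between 1.5 nM and 12 nM.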

Compound 4, antagonist equilibrium constant: 10.1 nM
Compound 4: middle estimate off by 2.5-fold (0.40 log units), on the low side; measured number inside the range.
By their numbers in this assay, from the lowest: compounds 2, 1 and 4 (each within the scatter of the next, the first and the last beyond it); then compound 3.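

In this assay, methyl on this aromatic carbon, two ring bonds from the ring atom that bears a large group, gives a 2.0-fold higher number from compound 1 to compound 4 (0.30 log units; within the scatter), so this single change does not separate the two compounds. The step with hydrogen in place of methyl on an aromatic carbon, a 3.7-fold higher number from compound 2 to compound 4 (0.57 log units; beyond the scatter), is modest but does reach beyond the scatter, so a difference of one methyl can be read in this series when it starts from the 4,5-dimethyl-1H-imidazol-1-yl group. No measurement offered here explains either step. Still open, from the compounds shown here alone, is how an ethyl group or a methoxy group on this aromatic carbon would read, and whether a lone methyl on the other ring carbon of compound 2 would read the same.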